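The compounds below may be only part of what the source reports. "The series", "measured", "known", "first", "only" and "open" are said of these compounds alone.

Measured so far:
- compound 1 `NC1=NC2(CCOCC2)N(OCCCOc2ccc(F)cc2)C(N)=N1`: "not determined" (no result reported)
- compound 2 `NC1=NC2(CCSCC2)N(OCCCOc2cccc(Cl)c2Cl)C(N)=N1`: 50 nM

Within the data shown here, in a functional assay on HepG2 cells (Homo sapiens) for antiproliferative activity, read by MTT assay, with a stated time of 72 h (a lower number here means a stronger inhibitor, a higher number a weaker inhibitor), compound 2 gives 50 nM, the only number, so it has no measured neighbour to be ranked against. Compound 3 `COc1ccc(OCCCON2C(N)=NC(N)=NC23CCSCC3)cc1` keeps the rest of compound 2 and changes one group: 4-methoxyphenyl in place of 2,3-dichlorophenyl on an oxygen on a saturated carbon. Among the measured compounds shown here, no step between measured compounds is available to size this change, so the expectation is loose: a moderate loss of potency, not a gain. The expected move is a 3.0-fold higher number from compound 2 to compound 3 (0.48 log units; beyond the scatter). The estimate for compound 3 is 150 nM, with an expected range of 30 nM to 800 nM.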

Compound 3, half-maximal inhibitory concentration: 880 nM
Compound 3: middle estimate off by 5.9-fold (0.77 log units), on the low side; measured number outside the range, above it.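

In this assay, 4-methoxyphenyl in place of 2,3-dichlorophenyl on an oxygen on a saturated carbon gives an 18-fold higher number from compound 2 to compound 3 (1.25 log units; beyond the scatter) and is a large step. This place in the series is therefore sensitive to the choice of aryl group, even though both groups have 8 heavy atoms and one six-membered aromatic ring of carbon only. No measurement bears on what underlies the step.

This single step does not separate the loss of the two chlorines from the gain of methoxy. On these data alone, how an amine or a carboxylic acid on the ring would read here remains open.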